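Furan-to-thiophene swap at the ring carbon of compound 2

The compounds below may be only part of what the source reports. "The series", "measured", "known", "first", "only" and "open" are said of these compounds alone.

Among the measured compounds shown here, compound 2 `CC1=C(C(=O)OCc2ccccc2)C(c2ccoc2)NC(=O)N1C` stands highest of the two numbers measured so far: in an assay on membranes from HEK293 cells for displacement of a labelled ligand from adenosine receptor A2b (Homo sapiens), read by scintillation counting, with a stated time of 30 min, tested at 1 uM (a higher number here means more inhibition at the concentration tested (going by the name of the read-out), a lower number less inhibition), compound 2 gives 49%. Its nearest neighbour is compound 1 `CC1=C(C(=O)OCC(C)C)C(c2ccoc2)NC(=O)N1C`, which in this assay gives 1%. For the measured compounds named here, the single measured step between them, a number 48 percentage points higher from compound 1 to compound 2 (beyond the scatter), concerns only the ester side of the shared core, where phenyl replaces isopropyl on the saturated chain carbon bound to the oxygen next to the carbonyl group.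

Compound 3 `CC1=C(C(=O)OCc2ccccc2)C(c2cccs2)NC(=O)N1C` is the next compound for this assay. It differs from compound 2 at a different place: thiophen-2-yl in place of furan-3-yl on a saturated ring carbon. The five-membered aromatic ring changes from furan-3-yl to thiophen-2-yl, with the same count of heavy atoms, donors and acceptors.

Going by the values given here, no measured step touches this saturated ring carbon, so the large step from compound 1 to compound 2 gives no direct guide here. With nothing in the series pointing in either direction, the expected step from compound 2 to compound 3 in this assay is a number 4 percentage points lower from compound 2 to compound 3 (within the scatter), that is, none beyond the scatter. Compound 3 is therefore estimated at 45% in this assay, within a range of 20% to 70%.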

Compound 3, a percentage reported as inhibition, at one concentration (the size of the read-out at that concentration, not a potency): 50%
Compound 3: middle estimate off by 5 percentage points, on the low side; the range from low to high includes it.
By their numbers in this assay, from the lowest: compound 1; then compounds 2 and 3 (each within the scatter of the next).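

Working notes: this is the first measured step at the saturated ring carbon of the shared core. In this assay the exchange of furan-3-yl for thiophen-2-yl gives a number 1 percentage points higher from compound 2 to compound 3 (within the scatter), so at this position, with the phenyl-bearing ester kept in place, the two five-membered aromatic rings cannot be told apart by this read-out. The change swaps the ring oxygen for sulfur and moves the point of attachment in a single step, so neither part can be read alone, and no supporting measurement bears on why the two rings read alike.

From the compounds shown here alone, it remains open whether the position stays this flat for groups outside this pair, such as furan-2-yl, thiophen-3-yl, an unsubstituted phenyl ring, a saturated cyclohexyl ring or a ring carrying an amine. Going by these compounds, it is also open whether the large ester step seen with furan-3-yl, a number 48 percentage points higher from compound 1 to compound 2 (beyond the scatter), carries over when thiophen-2-yl occupies the ring carbon, which would take the ester of compound 1 paired with thiophen-2-yl.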